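Shortening the chain of compound 3: working notes

This account rests on a few compounds, and the source may have more. Where it says the series, first, only, none or still open, it means among the compounds named here.

Measured so far in a functional assay on PC-3 cells (Homo sapiens) for antiproliferative activity, read by MTT assay, with a stated time of 72 h; a higher number here means a weaker inhibitor, a lower number a stronger inhibitor:
- compound 1 `CCCCCCCCNC[C@@H]1OC[C@H](N)[C@@H]1O` gives 13800 nM
- compound 2 `CCCCCCCNC[C@@H]1OC[C@H](N)[C@@H]1O` gives 22400 nM
- compound 3 `CCCCCCCCCCCCCCNC[C@@H]1OC[C@H](N)[C@H]1O` gives 1990 nM

Compound 3 has the lowest of the three values, and its gaps to compound 1 and compound 2 both lie beyond the scatter. The next case is compound 4 `CCCCCCCCCCNC[C@@H]1OC[C@H](N)[C@H]1O`, not yet measured. The structural change is hydrogen in place of butyl on a saturated chain carbon, ten or more bonds along the chain from an amine nitrogen and it is hydrogen in place of butyl on a saturated chain carbon, ten or more bonds along the chain from an amine nitrogen.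

For the measured compounds named here, only one measured step bears on this: a 1.6-fold higher number from compound 1 to compound 2 (0.21 log units; within the scatter) for hydrogen in place of methyl, seven bonds along the chain from an amine nitrogen. That step stays within the scatter, but it removes less than butyl, so it sets no size for this change. A step beyond the scatter toward a higher number is expected, with compound 1 at 13800 nM as a rough reference for the upper end. The estimate means an expected 3.0-fold higher number from compound 3 to compound 4 (0.48 log units; beyond the scatter) in this assay. The estimated value for compound 4 is 6000 nM with an expected range from 2800 nM to 14000 nM.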

Compound 4, half-maximal inhibitory concentration: > 128000 nM
Compound 4 ended at the assay's limit; the forecaster's own chance of this, stated with the estimate: 3%; middle value at least 21-fold (1.32 log units) away from the limit.
By their numbers in this assay, from the lowest: compound 3; then compounds 1 and 2 (each within the scatter of the next). At a limit, above all of these: compound 4.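

Hydrogen in place of butyl on a saturated chain carbon gives an at least 64-fold higher number from compound 3 to compound 4 (1.80 log units; beyond the scatter) in this assay, so on the core of compound 3 this single change is enough to reach the limit of the assay. For the compounds shown here, the only earlier step, a 1.6-fold higher number from compound 1 to compound 2 (0.21 log units; within the scatter), stays within the scatter, but it concerns hydrogen in place of methyl on the core of compound 1 and gave no sign of a change this large. The value of compound 4, > 128000 nM, is a limit and not a number: the limit of > 128000 nM in this assay, at which 1 of the 4 values shown sits.

The compounds shown leave open how the value moves for a chain of intermediate length on the core of compound 3, such as a dodecyl chain. Also open, as far as these compounds go, is whether a longer chain than that of compound 3 would give a lower number.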